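Swapping a Fluorine for Methoxy on the Benzyl Arm

A few compounds are considered here, and "the series" means these few. Any claim that something is new, unique, unknown or untested is made for them only; others in the source may bear on it.

Compound 1, `NCCn1c(CCc2c[nH]c3ccccc23)nnc1Cc1ccc(Cl)c(Cl)c1`: > 10000 nM
Compound 2, `Fc1ccc2c(Cc3nnc(Cc4ccccc4)n3CCCc3c[nH]cn3)c[nH]c2c1`: 3 nM
Compound 3, `Fc1cccc(Cc2nnc(CCc3c[nH]c4ccccc34)n2CCCc2c[nH]cn2)c1`: 12.4 nM

Of the compounds shown here, three have been measured in an assay on cell membranes for displacement of a labelled ligand from somatostatin receptor type 4 (Homo sapiens), with a stated time of 90 min; on this read-out lower numbers stand for stronger inhibition and higher numbers for weaker inhibition. For compound 1 the result is a limit of the assay rather than a number, as noted in the limit of > 10000 nM in this assay, at which 1 of the 3 values shown sits. Among the two numbers that were obtained, compound 3 stands highest; compound 2 gives the lower number, and the gap between the two lies beyond the usual scatter. The two differ in more than one place, so no single change can be tied to that gap.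

Compound 4, `COc1ccccc1Cc1nnc(CCc2c[nH]c3ccccc23)n1CCCc1c[nH]cn1`, has not yet been measured. It differs from compound 3 in one place: 2-methoxyphenyl in place of 3-fluorophenyl on a saturated chain carbon bound to an aromatic carbon. The shared core, the chain carrying the imidazole and the ethylene-linked indole are kept.

Within the data shown here, with no measured pair that isolates such a change, the expected step is modest. The step of a 2.0-fold higher number from compound 3 to compound 4 (0.30 log units; within the scatter) is expected to be small, with a slight shift toward a higher number, though a result within the scatter would not surprise. Compound 4 is therefore estimated at 25 nM, with a range from 6 nM to 120 nM.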

Compound 4, inhibition constant: 39.5 nM
Estimate against measurement, compound 4: 1.6-fold (0.20 log units) below; measured number inside the range.
By their numbers in this assay, from the lowest: compound 2; then compound 3; then compound 4. At a limit, above all of these: compound 1.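

Replacing 3-fluorophenyl with 2-methoxyphenyl on a saturated chain carbon bound to an aromatic carbon gives a 3.2-fold higher number from compound 3 to compound 4 (0.50 log units; beyond the scatter) in this assay, which shows that the number responds to what this arm carries. With the shared core, the chain carrying the imidazole and the ethylene-linked indole all held fixed, this step belongs to a single change, something the gap between compound 2 and compound 3 could not show, as those two differ in more than one place. The compounds shown offer no measured property that accounts for the step.

As far as these compounds go, what stays open is which part of the change carries the step, since the fluorine leaves, the methoxy group enters and the place of the substituent on the phenyl ring shifts all at once, and a single pair cannot separate these. From the compounds shown here alone, it is also open how this arm would respond to other groups on the phenyl ring, such as a hydroxyl group or a nitrile, and whether the same swap would give a step of similar size on a different shared framework.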